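This account rests on a few compounds, and the source may have more. Where it says the series, first, only, none or still open, it means among the compounds named here.

Compound 1, `Cc1ccc(CCc2cc3cn([C@H]4C[C@H](O)[C@@H](CO)O4)c(=O)nc3o2)cc1`: 540000 nM
Compound 2, `CCCc1ccc(CCc2cc3cn([C@H]4C[C@H](O)[C@@H](CO)O4)c(=O)nc3o2)cc1`: >= 130000 nM
Compound 3, `CCCCc1ccc(-c2cc3cn([C@H]4C[C@H](O)[C@@H](CO)O4)c(=O)nc3o2)nc1`: > 100000 nM

All three were tested in an ADME assay on HEL cells (Homo sapiens) for cytotoxicity, with a stated time of 3 days; a higher number here means that more compound is tolerated, a lower number that less compound is tolerated. For compound 2 the value >= 130000 nM is a limit of the assay, not a number. For compound 3 the value > 100000 nM is likewise a limit. Compound 1 gives a plain number in this assay, 540000 nM. The change from compound 1 to compound 2 is ethyl in place of hydrogen on a saturated chain carbon bound to an aromatic carbon, and the step it made, a step that the limit leaves unreadable from compound 1 to compound 2, cannot be read, due to the limit of >= 130000 nM in this assay, at which 1 of the 3 values shown sits. Compound 4, `CCCCCCc1ccc(-c2cc3cn([C@H]4C[C@H](O)[C@@H](CO)O4)c(=O)nc3o2)nc1`, is not yet measured. It differs from compound 3 by ethyl in place of hydrogen on a saturated chain carbon, four bonds along the chain from an aromatic carbon. The place is not the same as in the pair of compound 1 and compound 2, where the chain carbon is bound to an aromatic carbon rather than four bonds along the chain from one, so the two changes are of the same kind, not the same. The difference between the core of compound 1 and the core of compound 3 is not broken down here. The step from compound 3 to compound 4 is expected to be roughly a number no higher from compound 3 to compound 4 (the limit leaves the size open), which rests on the unreadable step of compound 1 to compound 2 and on the limit of compound 3. Compound 4 is therefore estimated at 100000 nM in this assay, between 30000 nM and 300000 nM.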

Compound 4, minimum cytotoxic concentration: > 100000 nM
Compound 4: only a limit was reported (the forecaster's own chance of this, stated with the estimate: 50%); the middle value lies on the limit itself.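

No step can be read between compound 3 and compound 4, due to the limit that both values share: the limit of > 100000 nM in this assay, at which 2 of the 4 values shown sit.

The compounds shown leave open whether ethyl in place of hydrogen on a saturated chain carbon, four bonds along the chain from an aromatic carbon, changes the result in this assay at all, and by how much.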